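Ethynyl for cyano on the aminophenyl ring of the series

A few compounds are considered here, and "the series" means these few. Any claim that something is new, unique, unknown or untested is made for them only; others in the source may bear on it.

Compound 1 `C[Si](C)(C)C#Cc1cc(-c2nc3cc(F)ccc3s2)ccc1N` gives 210 nM in a functional assay on MDA-MB-468 cells (Homo sapiens) for inhibition, with a stated time of 72 h; on this read-out lower numbers stand for stronger inhibition of growth and higher numbers for weaker inhibition of growth. Compound 2 `N#Cc1cc(-c2nc3ccc(F)cc3s2)ccc1N` gives 320 nM in this assay. Compound 3 `N#Cc1cc(-c2nc3ccccc3s2)ccc1N` gives 340 nM in this assay.

All three numbers fall within the usual scatter of one another, so no ranking is warranted; compound 2 and compound 3 differ only by a 1.1-fold higher number from compound 2 to compound 3 (0.03 log units; within the scatter), and compound 1 with its silyl-capped alkyne sits close to compound 2 as well. Compound 4 `C#Cc1cc(-c2nc3ccc(F)cc3s2)ccc1N` is the next entry: ethynyl in place of cyano on an aromatic carbon. Within the data shown here, the only measured step concerns a fluoro elsewhere and does not bear on this change; the value of compound 1, however, suggests an alkyne at this position is tolerated. Compound 4 is therefore expected at 280 nM (range 120 nM to 650 nM), a step of a 1.1-fold lower number from compound 2 to compound 4 (0.06 log units; within the scatter), estimated within the scatter.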

Compound 4, concentration for 50% growth inhibition: 23 nM
Beside the measured number, compound 4's estimate is 12-fold (1.09 log units) above it, and the stated range ends above it.
By their numbers in this assay, from the lowest: compound 4; then compounds 1, 2 and 3 (each within the scatter of the next).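

In this assay, the position ortho to an amino group proves sensitive to the choice of group: ethynyl in place of cyano gives a 14-fold lower number from compound 2 to compound 4 (1.14 log units; beyond the scatter). From the compounds shown here alone, both groups have the same heavy-atom count and a triple bond, so these counts alone do not set the value; cyano carries a hydrogen-bond acceptor and ethynyl does not, but that link remains untested. No measurement at hand explains the step.

Open, going by these compounds, is whether a propynyl group or an aminomethyl group at this position would keep the value of compound 4. Also open, on these data alone, is whether the fluoro matters as little with ethynyl as in the cyano pair, a 1.1-fold higher number from compound 2 to compound 3 (0.03 log units; within the scatter).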